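Methoxy for methyl in a urea series without cytotoxic signal

A few compounds are considered here, and "the series" means these few. Any claim that something is new, unique, unknown or untested is made for them only; others in the source may bear on it.

Compound 1 `Cc1ccc(NC(=O)Nc2cc(C)nc3ccccc23)cc1` was tested in an ADME assay on HEK293 cells (Homo sapiens) for cytotoxicity, with a stated time of 72 h; a higher number here means that more compound is needed for the effect, a lower number that less compound is needed. In this assay compound 1 gives only a limit, > 25000 nM. Compound 2 `Cc1cc(NC(=O)Nc2cccnc2)c2ccccc2n1` likewise gives a limit in this assay, > 25000 nM. Compound 3 `Cc1cc(NC(=O)Nc2ncccc2C)c2ccccc2n1` also reaches only a limit, > 25000 nM. Hence a step that the two limits leave unreadable from compound 1 to compound 2, a step that the two limits leave unreadable from compound 1 to compound 3 and a step that the two limits leave unreadable from compound 2 to compound 3 cannot be sized because of the limit of > 25000 nM in this assay, at which 3 of the 3 values shown sit. Compound 4 `COc1ccc(NC(=O)Nc2cc(C)nc3ccccc23)cc1` differs from compound 1 in one place: methoxy in place of methyl on an aromatic carbon. Among the compounds with values here, none of the measured steps bears on this change, and all three measured compounds sit at the limit, so no step beyond the scatter can be read in either direction. Compound 4 is therefore expected to give 40000 nM, with a range from 15000 nM to 150000 nM, most likely once more as a limit. The expected step is a step that the limit leaves unreadable from compound 1 to compound 4.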

Compound 4, half-maximal effective concentration: > 25000 nM
Compound 4 gave a limit, no number (the forecaster's own chance of this, stated with the estimate: 85%); the middle value does not contradict the limit.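

Compound 4 adds no readable step to compound 1, because both remain limits in this assay: the limit of > 25000 nM in this assay, at which 4 of the 4 values shown sit.

The compounds shown leave open whether methoxy in place of methyl changes the result in this assay at all, and at what concentration any of the four compounds would give a number.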